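The source may report more compounds than this note shows. Statements on the series, on what has been measured and on what is new or still open speak of the compounds shown alone.

Compound 1 `COc1ccc(S(=O)(=O)Nc2ccc(-c3nc4ccccc4o3)cc2)cc1`: in an assay on cells for inhibition of HSP60/HSP10 (Homo sapiens), with a stated time of 60 min (on this read-out lower numbers stand for stronger inhibition and higher numbers for weaker inhibition), compound 1 gives > 100000 nM, which is a limit of the assay.
Compound 2 `O=S(=O)(Nc1ccc(-c2nc3ccccc3o2)cc1)c1ccccc1O`: in this assay compound 2 gives > 100000 nM, again a limit.
Compound 3 `CS(=O)(=O)Nc1ccc(-c2nc3ccccc3o2)cc1`: in this assay compound 3 gives > 100000 nM, also a limit.

Compound 3 therefore stands at the limit, where every measured value sits (the limit of > 100000 nM in this assay, at which 3 of the 3 values shown sit), so it cannot be ranked against compounds 1 and 2. The next compound, compound 4 `O=S(=O)(Nc1ccc(-c2nc3ccccc3o2)cc1)c1ccc(Cl)cc1`, differs from compound 3 in one place: 4-chlorophenyl in place of methyl on a sulfonyl sulfur. For the measured compounds named here, the steps that bear on this change are a step that the two limits leave unreadable from compound 1 to compound 3 and a step that the two limits leave unreadable from compound 2 to compound 3, both of which exchange a group on the sulfonyl sulfur, and neither has a readable size. No direction can be drawn from them, and a value at the limit is expected for compound 4 too, estimated at 150000 nM (range 30000 nM to 1000000 nM), a step that the limit leaves unreadable from compound 3 to compound 4.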

Compound 4, half-maximal inhibitory concentration: 61000 nM
Compound 4: middle estimate off by 2.5-fold (0.39 log units), on the high side; low and high end bracket the measured number.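

For the compounds shown here, exchanging the group on the sulfonyl sulfur now gives a readable number for the first time: 4-chlorophenyl in place of methyl gives an at least 1.6-fold lower number from compound 3 to compound 4 (0.21 log units; that floor lies within the scatter), and in place of 2-hydroxyphenyl it gives an at least 1.6-fold lower number from compound 2 to compound 4 (0.21 log units; that floor lies within the scatter). Chloro in place of methoxy on an aromatic carbon gives an at least 1.6-fold lower number from compound 1 to compound 4 (0.21 log units; that floor lies within the scatter). Each step is only a floor, set by a limit of the assay: the limit of > 100000 nM in this assay, at which 3 of the 4 values shown sit.

On these data alone, it remains open whether the chloro is needed or the aromatic ring alone is enough, and what an unsubstituted phenyl or a 4-carboxyphenyl on the sulfonyl sulfur would give.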